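A few compounds are considered here, and "the series" means these few. Any claim that something is new, unique, unknown or untested is made for them only; others in the source may bear on it.

Of the compounds shown here, three built on one shared core have been measured in an ADME assay on MT4 cells (Homo sapiens) for cytotoxicity, read by MTT assay; a lower number here means that less compound is tolerated, a higher number that more compound is tolerated. Compound 1 `Cc1cc(C)cc(S(=O)(=O)c2c(C(=O)Nc3ccccc3O)[nH]c3ccc(Cl)cc23)c1` gives 19700 nM. Compound 2 `Cc1cc(C)cc(S(=O)(=O)c2c(C(=O)Nc3cccc(O)c3)[nH]c3ccc(Cl)cc23)c1` gives 24600 nM, and compound 3 `Cc1cc(C)cc(S(=O)(=O)c2c(C(=O)NCc3cccc(O)c3)[nH]c3ccc(Cl)cc23)c1` gives 27000 nM. Compound 1 carries the smallest of these three numbers, yet its distance to compound 2 is a 1.2-fold higher number from compound 1 to compound 2 (0.10 log units; within the scatter) and its distance to compound 3 is a 1.4-fold higher number from compound 1 to compound 3 (0.14 log units; within the scatter), so none of the three can be told apart on this assay.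

Compound 4 `Cc1cc(C)cc(S(=O)(=O)c2c(C(=O)NCc3ccc(O)cc3)[nH]c3ccc(Cl)cc23)c1` has not yet been measured. It differs from compound 1 in one place: 4-hydroxybenzyl in place of 2-hydroxyphenyl on an amide-type nitrogen. The measured steps that bear on this change are the ones that also exchange the group on the amide-type nitrogen, namely the two just named and a 1.1-fold higher number from compound 2 to compound 3 (0.04 log units; within the scatter), all of which stayed within the scatter. Among the compounds with values here, exchanging one hydroxyphenyl or hydroxybenzyl group for another has therefore not shifted this assay so far, and no shift beyond the scatter is expected here: the step is estimated as a 1.2-fold higher number from compound 1 to compound 4 (0.09 log units; within the scatter). Compound 4 is expected to give about 24000 nM, within a range from 13000 nM to 45000 nM.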

Compound 4, half-maximal cytotoxic concentration: 6250 nM
Compound 4: the middle estimate sits 3.8-fold (0.58 log units) above what was measured; the measured number lies below the stated range.
By their numbers in this assay, from the lowest: compound 4; then compounds 1, 2 and 3 (each within the scatter of the next).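

In this assay, the group on the amide-type nitrogen turns out not to be interchangeable after all: moving to 4-hydroxybenzyl gives a 3.2-fold lower number from compound 1 to compound 4 (0.50 log units; beyond the scatter) and a 3.9-fold lower number from compound 2 to compound 4 (0.60 log units; beyond the scatter). The most telling comparison is a 4.3-fold lower number from compound 3 to compound 4 (0.64 log units; beyond the scatter), as both compounds carry a benzyl group and differ only in 4-hydroxyphenyl against 3-hydroxyphenyl on the saturated chain carbon, so the benzyl chain alone does not go with the shift, and where the hydroxyl sits on the ring does. Nothing available explains this shift.

The compounds shown leave open whether the 4-hydroxy placement has the same effect without the chain carbon, as in a 4-hydroxyphenyl group on the amide-type nitrogen. They also leave open whether the hydroxyl itself is needed, which a 4-aminobenzyl or 4-methoxybenzyl group would address.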